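A few compounds are considered here, and "the series" means these few. Any claim that something is new, unique, unknown or untested is made for them only; others in the source may bear on it.

Three close relatives sharing one core have been tested in a functional assay on OVCAR-8 cells (Homo sapiens) for antiproliferative activity; a lower number here means a stronger inhibitor, a higher number a weaker inhibitor. Compound 1 `Cn1ncc(Cl)c1-c1cc(C(=O)N[C@@H]2CN[C@H](CC(O)CO)C[C@H]2c2ccc(Cl)c(Cl)c2)oc1Cl` gives 1610 nM. Compound 2 `Cn1ncc(Cl)c1-c1cc(C(=O)N[C@@H]2CN[C@H](CCN3CCCCC3)C[C@H]2c2ccc(Cl)c(Cl)c2)oc1Cl` gives 1660 nM, and compound 3 `Cn1ncc(Cl)c1-c1cc(C(=O)N[C@@H]2CN[C@H](CC(=O)O)C[C@H]2c2ccc(Cl)c(Cl)c2)oc1Cl` gives 5120 nM. Of the three numbers, compound 1 holds the smallest, yet the step of a 1.0-fold higher number from compound 1 to compound 2 (0.01 log units; within the scatter) is within the usual scatter, so the first two cannot be told apart; only compound 3 stands clearly apart, as the steps of a 3.2-fold higher number from compound 1 to compound 3 (0.50 log units; beyond the scatter) and a 3.1-fold higher number from compound 2 to compound 3 (0.49 log units; beyond the scatter) show.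

Compound 4 `Cn1ncc(Cl)c1-c1cc(C(=O)N[C@@H]2CN[C@H](CCN3CCCC3)C[C@H]2c2ccc(Cl)c(Cl)c2)oc1Cl` has not yet been measured. Its difference from compound 1 is (pyrrolidin-1-yl)methyl in place of 1,2-dihydroxyethyl on a saturated chain carbon bound to a saturated ring carbon. The measured step that bears most directly on this change is the one in which a (piperidin-1-yl)methyl took the place of the same 1,2-dihydroxyethyl, and that step, a 1.0-fold higher number from compound 1 to compound 2 (0.01 log units; within the scatter), stayed within the scatter. A (pyrrolidin-1-yl)methyl is a close relative of a (piperidin-1-yl)methyl, so a similar outcome seems likely. The carboxy replacement pointed the other way, but it is a different kind of group. The expected step is therefore none beyond the scatter, a 1.0-fold higher number from compound 1 to compound 4 (0.01 log units; within the scatter). Compound 4 is estimated at 1650 nM, with a range from 800 nM to 3400 nM.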

Compound 4, half-maximal inhibitory concentration: 1840 nM
The estimate for compound 4 lay 1.1-fold (0.05 log units) below the measured number, within the range that was stated.
By their numbers in this assay, from the lowest: compounds 1, 2 and 4 (each within the scatter of the next); then compound 3.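

In this assay, pyrrolidin-1-yl in place of piperidin-1-yl at the end of the chain gives a step within the scatter (a 1.1-fold higher number from compound 2 to compound 4 (0.04 log units; within the scatter)), so the two ring amines cannot be told apart at this position. The 2-(pyrrolidin-1-yl)ethyl chain also cannot be separated from the 2,3-dihydroxypropyl chain (a 1.1-fold higher number from compound 1 to compound 4 (0.06 log units; within the scatter)), which means a second amine now matches the diol, and two different ring amines rest level with it rather than a single example. Compound 3, with its carboxy group, remains the only one set apart, and the gap appears again against this second amine (a 2.8-fold lower number from compound 3 to compound 4 (0.44 log units; beyond the scatter)), so the modest separation of the carboxy compound does not depend on one particular amine partner.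

No measurement beyond these cell numbers is available to explain why the three compounds group as they do. As far as these compounds go, it remains open whether an open-chain amine such as a dimethylamino group, a morpholine ring, a simple primary amine, or a shorter or longer chain carrying the same pyrrolidine would stay level with compounds 1, 2 and 4, and whether an ester or amide of the carboxylic acid would sit with them or with compound 3.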